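Swapping a Pyridine Amide for a Cyclohexane Amide

The source may report more compounds than this note shows. Statements on the series, on what has been measured and on what is new or still open speak of the compounds shown alone.

Compound 1 `COc1ccc(-c2cnc(NC(=O)c3cccnc3)n2C)cc1`: > 100000 nM
Compound 2 `COc1ccccc1-c1cnc(NC(=O)c2ncc[nH]2)n1C`: > 50000 nM

In a toxicity assay on THP-1 cells (Homo sapiens) for inhibition (a lower number here means that less compound is tolerated, a higher number that more compound is tolerated), compound 1 gives > 100000 nM, which is a limit of the assay and not a number. Compound 2 gives > 50000 nM in this assay, likewise a limit. Compound 1 thus stands only at a limit, as the limit of > 100000 nM in this assay, at which 1 of the 2 values shown sits, shows, and the limit of > 50000 nM in this assay, at which 1 of the 2 values shown sits, is the other limit seen. Compound 3 `COc1ccc(-c2cnc(NC(=O)C3CCCCC3)n2C)cc1` differs from compound 1 by cyclohexyl in place of pyridin-3-yl on a carbonyl carbon. Going by the values given here, no step between measured compounds is available, so no shift beyond the scatter is expected in this assay. Compound 3 is expected to give 100000 nM, within 30000 nM to 300000 nM. The step of a number no higher from compound 1 to compound 3 (the limit leaves the size open) is estimated to be negligible.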

Compound 3, half-maximal cytotoxic concentration: > 100000 nM
Compound 3: no number, only a limit; the forecaster's own chance of this, stated with the estimate: 70%; the middle value lies on the limit itself.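

In this assay, going by these compounds alone, compound 1 and compound 3 both stand at a limit and not a number, so no step between them can be read: the limit of > 100000 nM in this assay, at which 2 of the 3 values shown sit. The compounds shown leave open what value lies behind each limit, and so whether cyclohexyl and pyridin-3-yl differ here at all.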